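The source may hold more compounds than are shown below. What is called first, only, known or untested is meant among the compounds shown, and "the series" means these compounds.

Measured in a functional assay on SiHa cells (Homo sapiens) for inhibition, read by sulforhodamine B assay; on this read-out lower numbers stand for stronger inhibition of growth and higher numbers for weaker inhibition of growth:
- compound 1 `c1ccc(-c2ccc(-c3ccc(-c4nc5ccccc5[nH]4)cc3)cc2)cc1`: 100000 nM
- compound 2 `COc1ccc(-c2ccc(-c3ccc(-c4nc5cc(C)ccc5[nH]4)cc3)cc2)cc1OC`: 3510 nM
- compound 3 `FC(F)(F)Oc1ccc(-c2ccc(-c3ccc(-c4nc5ccccc5[nH]4)cc3)cc2)cc1`: 38400 nM

Compound 3, at 38400 nM, holds the middle place among these three numbers. Compound 1 lies on its higher side and compound 2 on its lower side.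

The next compound to consider is compound 4 `COc1ccc(-c2ccc(-c3ccc(-c4nc5ccccc5[nH]4)cc3)cc2)cc1`, which has not yet been measured. It is reached from compound 3 by a single change: methyl in place of trifluoromethyl on an oxygen on an aromatic ring. In words, methyl takes the place of trifluoromethyl on an oxygen on an aromatic ring, so trifluoromethoxy becomes methoxy.

Among the compounds with values here, no measured step makes this exchange directly. The nearest evidence is a 2.6-fold lower number from compound 1 to compound 3 (0.42 log units; beyond the scatter), where trifluoromethoxy replaces hydrogen on an aromatic carbon. That step is modest, and it suggests that a substituent at this site can shift the number by a moderate amount. Compound 2, at 3510 nM, also carries methoxy, but it differs from compound 3 in other places too, so it gives only a weak hint of direction.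

A modest move towards stronger inhibition of growth is therefore expected, with real uncertainty about its direction. The expected change is a 2.4-fold lower number from compound 3 to compound 4 (0.38 log units; beyond the scatter). For compound 4 the estimate is 16000 nM, with an expected range from 4000 nM to 60000 nM.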

Compound 4, concentration for 50% growth inhibition: 2760 nM
Estimate against measurement, compound 4: 5.8-fold (0.76 log units) above; the whole stated range lies above it.
By their numbers in this assay, from the lowest: compounds 4 and 2 (each within the scatter of the next); then compound 3; then compound 1.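

In this assay, within the data shown here, the group on the oxygen turns out to matter far more than the earlier compounds suggested, for methyl in place of trifluoromethyl gives a 14-fold lower number from compound 3 to compound 4 (1.14 log units; beyond the scatter) in this single exchange. Measured against hydrogen on the same aromatic carbon, methoxy gives a 36-fold lower number from compound 1 to compound 4 (1.56 log units; beyond the scatter) while trifluoromethoxy gives only a 2.6-fold lower number from compound 1 to compound 3 (0.42 log units; beyond the scatter) so, in these compounds, the size of the step at this position depends strongly on what the oxygen carries and not on the presence of the oxygen alone. No available evidence bears on why these two groups on the oxygen differ so widely.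

The compounds shown leave open whether a longer chain on the oxygen, such as ethyl, would hold the number reached by methoxy, and whether a hydroxyl group or an amine on the same aromatic carbon would fall closer to methoxy or to hydrogen. Among these compounds, this exchange is also seen in only one pair, so whether methyl in place of trifluoromethyl gives a step of similar size on another core remains unknown.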